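Indole in place of phenyl on a weak cytotoxic amide

The compounds below may be only part of what the source reports. "The series", "measured", "known", "first", "only" and "open" are said of these compounds alone.

Compound 1 `CCCCCCCCCCCCNC(=O)[C@@H](NC(=O)c1ccccc1)[C@@H](C)O`: 63900 nM in a functional assay on SiHa cells (Homo sapiens) for cytotoxicity, read by MTT assay, with a stated time of 48 h; a higher number here means a weaker inhibitor, a lower number a stronger inhibitor
Compound 2 `CCCCCCCCCCCCCCNC(=O)[C@@H](NC(=O)c1ccccc1)[C@@H](C)O`: > 200000 nM in this assay

In this assay compound 1 gives 63900 nM. Compound 2 stands at a limit: in this assay compound 2 gives > 200000 nM, a limit of the assay rather than a number (the limit of > 200000 nM in this assay, at which 1 of the 2 values shown sits). Among the measured compounds shown here, the one measured step, an at least 3.1-fold higher number from compound 1 to compound 2 (0.49 log units; beyond the scatter), concerns only the chain. Compound 3 `CCCCCCCCCCCCCCNC(=O)[C@@H](NC(=O)c1cc2ccccc2[nH]1)[C@@H](C)O` differs from compound 2 by 1H-indol-2-yl in place of phenyl on a carbonyl carbon. For the measured compounds named here, no measured step touches this change, so no size can be taken from the data. Compound 3 is therefore expected near 150000 nM, between 40000 nM and 400000 nM. The expected step of an at least 1.3-fold lower number from compound 2 to compound 3 (0.12 log units; that floor lies within the scatter) is none beyond the scatter, and a limit may again be reported.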

Compound 3, half-maximal inhibitory concentration: 14200 nM
Beside the measured number, compound 3's estimate is 11-fold (1.02 log units) above it, and the stated range ends above it.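

In this assay, 1H-indol-2-yl in place of phenyl on a carbonyl carbon gives an at least 14-fold lower number from compound 2 to compound 3 (1.14 log units; beyond the scatter). Among the compounds shown here, the earlier compounds differed only in the chain, so this is the first sign that the group on the carbonyl carbon also changes the read-out, and that a compound with the longer chain can give a measured number. The size of this step is only a floor, since compound 2 stands at a limit: the limit of > 200000 nM in this assay, at which 1 of the 3 values shown sits.

As far as these compounds go, it remains open whether a naphthalen-2-yl group, with no ring nitrogen, would act like 1H-indol-2-yl. From the compounds shown here alone, whether the change carries over to the shorter chain of compound 1 is also open.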